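A few compounds are considered here, and "the series" means these few. Any claim that something is new, unique, unknown or untested is made for them only; others in the source may bear on it.

Compound 1 `CC(C)(C)c1ccc(/C=C/C(=O)c2ccc(OCC(=O)N[C@H]3CCOC3=O)cc2)cc1` gives 17200 nM in a functional assay on MGC-803 cells (Homo sapiens) for antiproliferative activity, read by MTT assay, with a stated time of 72 h; on this read-out lower numbers stand for stronger inhibition and higher numbers for weaker inhibition.
Compound 2 `O=C(CNc1ccc(Cl)cc1Cl)N[C@H]1CCOC1=O` reaches only > 64000 nM in this assay, which is a limit of the assay and not a number.

Within the data shown here, compound 1 thus holds the only number in this assay. The other entry is the limit of > 64000 nM in this assay, at which 1 of the 2 values shown sits. Compound 3 `O=C(COc1ccc(C(=O)/C=C/c2ccc(Br)cc2)cc1)N[C@H]1CCOC1=O` is not yet measured in this assay. It differs from compound 1 by bromo in place of tert-butyl on an aromatic carbon. Among the measured compounds shown here, no step between measured compounds has been followed here, so only a modest change is expected, leaning slightly toward weaker inhibition, as the expected step of a 1.3-fold higher number from compound 1 to compound 3 (0.11 log units; within the scatter). Compound 3 is expected to give about 22000 nM, in a range from 8000 nM to 55000 nM.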

Compound 3, half-maximal inhibitory concentration: 51000 nM
The estimate for compound 3 lay 2.3-fold (0.37 log units) below the measured number; the measured number falls inside the stated range.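

In this assay the change from 4-(tert-butyl)phenyl to 4-bromophenyl gives a 3.0-fold higher number from compound 1 to compound 3 (0.47 log units; beyond the scatter) and so shows that this aromatic carbon responds to the group it carries. Of these two groups, tert-butyl goes with the stronger inhibition. The change swaps four carbon atoms for one bromine atom, so size and element change together, and nothing measured here bears on the reason for the step. The compounds shown leave open how a methoxy group, an amine or a carboxylic acid on this carbon would compare with bromo and tert-butyl.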